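The compounds below may be only part of what the source reports. "The series", "measured", "known", "first", "only" and "open" are said of these compounds alone.

Measured compounds: compound 1 `C[C@@H](Cn1c(=O)[nH]/c(=N\c2ccc(Oc3nccs3)cc2)n(Cc2ccc(Cl)cc2)c1=O)C(=O)O`, compound 2 `C[C@@H](Cn1c(=O)[nH]/c(=N\c2ccc(Oc3cccc(F)n3)cc2)n(Cc2ccc(Cl)cc2)c1=O)C(=O)O`, compound 3 `Cc1ccc(Cn2c(=O)n(CC(C)(C)C(=O)O)c(=O)[nH]/c2=N\c2ccc(OC(C)C)c(Cl)c2)cc1`. In an ADME assay on the whole organism (Rattus norvegicus) for pharmacokinetics, using cassette dosing, at a dose of 1 mg/kg by the oral route (on this read-out lower numbers stand for lower oral bioavailability and higher numbers for higher oral bioavailability), compound 1 gives 41.4%, compound 2 gives 60% and compound 3 gives 30.7%. Compound 2 stands highest of the three, with its gaps to compound 1 and to compound 3 both beyond the scatter. Compound 4 `C[C@@H](Cn1c(=O)[nH]/c(=N\c2ccc(OC3CCC3)cc2)n(Cc2ccc(Cl)cc2)c1=O)C(=O)O` differs from compound 2 by cyclobutyl in place of 6-fluoropyridin-2-yl on an oxygen on an aromatic ring. Among the measured compounds shown here, the one step that bears on this place is a number 18.6 percentage points higher from compound 1 to compound 2 (beyond the scatter), a modest shift for an exchange on an oxygen on an aromatic ring, while compound 3, which differs in more than one place, sits lowest. On that basis the cyclobutyl is expected to cost some of the advantage of compound 2, with a number 15 percentage points lower from compound 2 to compound 4 (beyond the scatter) as the expected step. Compound 4 is therefore estimated at 45%, within 25% to 65%.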

Compound 4, oral bioavailability: 54.3%
Beside the measured number, compound 4's estimate is 9.3 percentage points below it; low and high end bracket the measured number.
By their numbers in this assay, from the lowest: compound 3; then compound 1; then compounds 4 and 2 (each within the scatter of the next).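

In this assay, an aromatic ring on this oxygen proves unnecessary: a number 5.7 percentage points lower from compound 2 to compound 4 (within the scatter) and so cyclobutyl cannot be told apart from 6-fluoropyridin-2-yl, whereas a number 12.9 percentage points higher from compound 1 to compound 4 (beyond the scatter) and so cyclobutyl keeps the advantage over 1,3-thiazol-2-yl. At this place, a non-aromatic ring of carbon alone therefore serves as well as the fluorinated aromatic ring. Nothing available accounts for this result. The compounds shown leave open how an open chain such as n-butyl, or a ring carrying an amine such as piperidin-4-yl, would fare on this oxygen.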